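Cytotoxicity notes: aryl swap at the benzylic amine

The source may report more compounds than this note shows. Statements on the series, on what has been measured and on what is new or still open speak of the compounds shown alone.

Compound 3 `Cc1ccc2[nH]c(=O)c(CN(Cc3ccc(OC(F)F)cc3)Cc3ccc(C(C)(C)C)cc3)cc2c1` returns in a toxicity assay on MDCK cells (Canis lupus familiaris) for cytotoxicity, read by crystal violet staining, with a stated time of 48 h (on this read-out higher numbers stand for lower toxicity in this test and lower numbers for higher toxicity in this test), only a limit, > 5000 nM, so its place among the three measured compounds is an edge of the assay rather than a number. Compound 1 `Cc1ccc2[nH]c(=O)c(CN(Cc3ccc(O)cc3)Cc3ccc(C(C)(C)C)cc3)cc2c1` gives in this assay a reading of 4900 nM. Compound 2 `Cc1ccc2[nH]c(=O)c(CN(Cc3ccc(OCC(=O)OC(C)(C)C)cc3)Cc3ccc(C(C)(C)C)cc3)cc2c1` likewise returns in this assay only a limit, > 10000 nM. The measured steps that touch compound 3 are an at least 1.0-fold higher number from compound 1 to compound 3 (0.00 log units; that floor lies within the scatter) and a step that the two limits leave unreadable from compound 2 to compound 3; the first rests on (the limit of > 5000 nM in this assay, at which 1 of the 3 values shown sits), the second on the limit of > 10000 nM in this assay, at which 1 of the 3 values shown sits, together with the limit of > 5000 nM in this assay, at which 1 of the 3 values shown sits, and neither reads as a change in toxicity. Compound 4 `Cc1ccc2[nH]c(=O)c(CN(Cc3ccc(C(C)(C)C)cc3)Cc3ccc(N(C)C)c(Cl)c3)cc2c1` differs from compound 3 by 3-chloro-4-(dimethylamino)phenyl in place of 4-(difluoromethoxy)phenyl on a saturated chain carbon bound to an amine nitrogen. No measured step alters the group on this saturated chain carbon; the steps shown all concern the substituent on the oxygen, so they bear on the present change only by showing that toxicity in this assay stayed at or beyond the limit throughout. For compound 4 a step of a number no higher from compound 3 to compound 4 (the limit leaves the size open) within the scatter is expected. Compound 4 is estimated at 5000 nM, with a range of 2000 nM to 15000 nM.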

Compound 4, half-maximal cytotoxic concentration: > 10000 nM
Compound 4: only a limit was reported; the forecaster's own chance of this, stated with the estimate: 55%; at least 2.0-fold (0.30 log units) between middle value and limit.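

Compound 4 returns > 10000 nM in this assay, which is a limit of the assay and not a number: the limit of > 10000 nM in this assay, at which 2 of the 4 values shown sit.

Unlike the oxygen substituent changes, this change replaces the whole aryl group on a saturated chain carbon bound to an amine nitrogen, and 3-chloro-4-(dimethylamino)phenyl gives no readable toxicity in this assay. Measured against 4-hydroxyphenyl, the change gives an at least 2.0-fold higher number from compound 1 to compound 4 (0.30 log units; that floor lies within the scatter), while the step that joins two limits cannot be read.

What the compounds shown leave open is the actual cytotoxic concentration of compound 4 and whether the chlorine or the dimethylamino group governs that reading. Also open, on these data alone, is how a carboxylic acid or a primary amine on the aryl ring at this place would read in this assay.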